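Shortening the oxanyl amide chain in a pyridone series

The compounds below may be only part of what the source reports. "The series", "measured", "known", "first", "only" and "open" are said of these compounds alone.

Measured compounds in a physicochemical assay for solubility; a higher number here means a more soluble compound, a lower number a less soluble compound:
compound 1, `CNC(=O)c1cc(C(=O)NCCC2CCOCC2)cn(Cc2ccccc2)c1=O`: >= 127 ug/mL, a limit of the assay
compound 2, `CNC(=O)c1cc(C(=O)NC2CCC2)cn(Cc2ccccn2)c1=O`: >= 103 ug/mL, a limit of the assay
compound 3, `CNC(=O)c1ccc(=O)n(Cc2cc(Br)ccc2F)c1`: >= 143 ug/mL, a limit of the assay

Compound 1 stands at a limit in this assay, not at a number. The other two values are limits as well, as the limit of >= 103 ug/mL in this assay, at which 1 of the 3 values shown sits, the limit of >= 127 ug/mL in this assay, at which 1 of the 3 values shown sits, and the limit of >= 143 ug/mL in this assay, at which 1 of the 3 values shown sits, show, so no ordering among the three can be read. Compound 4 `CNC(=O)c1cc(C(=O)NC2CCOCC2)cn(Cc2ccccc2)c1=O` differs from compound 1 by oxan-4-yl in place of 2-(oxan-4-yl)ethyl on an amide-type nitrogen. For the measured compounds named here, no measured step between two compounds is available to set the size of this change. The step that the limit leaves unreadable from compound 1 to compound 4 is expected to be none beyond the scatter. Compound 4 is therefore estimated at 150 ug/mL, within 80 ug/mL to 300 ug/mL, and most likely reported again as a limit.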

Compound 4, solubility: >= 174 ug/mL
Compound 4 was reported as a limit; the forecaster's own chance of this, stated with the estimate: 75%; at least 1.1-fold (0.06 log units) between middle value and limit.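

In this assay compound 1 stands at a limit, >= 127 ug/mL. Compound 4 also stands at a limit, >= 174 ug/mL. No step can be read from compound 1 to compound 4. The compounds shown leave open whether oxan-4-yl in place of 2-(oxan-4-yl)ethyl on an amide-type nitrogen shifts solubility at all.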